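This account rests on a few compounds, and the source may have more. Where it says the series, first, only, none or still open, it means among the compounds named here.

Measured so far in a functional assay on HCT-116 cells (Homo sapiens) for cytotoxicity; a lower number here means a stronger inhibitor of growth, a higher number a weaker inhibitor of growth:
- compound 1 `CCCCCCNC(=O)c1cc(NCc2cc(O)ccc2O)ccc1O`: 17000 nM
- compound 2 `O=C(NCc1ccccc1)c1cc(NCc2cc(O)ccc2O)ccc1O`: 17000 nM

Going by the values given here, compound 1 stands level with compound 2, its only measured neighbour. The next compound to be tested is compound 3 `CCCCCCCCCCCCNC(=O)c1cc(NCc2cc(O)ccc2O)ccc1O`. Its structural change from compound 1 is hexyl in place of hydrogen on a saturated chain carbon, six bonds along the chain from an amide-type nitrogen, so the chain on the amide nitrogen grows longer.

Among the compounds with values here, only one measured step bears on this: no change at the digits printed from compound 1 to compound 2 (within the scatter). That step puts phenyl in place of pentyl and does not lengthen the chain, so it is weak evidence. Within the data shown here, no measured pair shows what added chain length does in this assay. Among the measured compounds shown here, with only that flat step as a guide, no step beyond the scatter is expected, though with much uncertainty. The estimate corresponds to an expected 1.4-fold lower number from compound 1 to compound 3 (0.15 log units; within the scatter). Compound 3 is expected at 12000 nM, with an estimated range from 3000 nM to 40000 nM.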

Compound 3, concentration for 50% growth inhibition: 2100 nM
For compound 3 the middle estimate is 5.7-fold (0.76 log units) above the measured one; measured number below the stated range.
By their numbers in this assay, from the lowest: compound 3; then compounds 1 and 2 (each within the scatter of the next).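

Going by these compounds alone, compound 3 carries hexyl in place of hydrogen on a saturated chain carbon, six bonds along the chain from an amide-type nitrogen, and in this assay this change gives an 8.1-fold lower number from compound 1 to compound 3 (0.91 log units; beyond the scatter) and is the first step in this small set to lie beyond the scatter. The earlier swap of pentyl for phenyl between compound 1 and compound 2 left the number flat, so only now does this chain prove able to move the growth-inhibition reading, here toward stronger inhibition. No measurement at hand explains the step.

From the compounds shown here alone, one pair cannot show a trend, so it remains open whether a longer chain would lower the number further or reverse the gain. Also open, going by these compounds, is whether a chain of this length ending in an amine or a carboxylic acid would keep the step.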